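Swapping 2-hydroxyphenyl for pyridin-2-yl: compound 3 to compound 4

This account rests on a few compounds, and the source may have more. Where it says the series, first, only, none or still open, it means among the compounds named here.

- compound 1 `CC(C)CN1C(=O)/C(=C/c2ccc(N(C)C)cc2)S/C1=N\c1ccccc1`: > 100000 nM
- compound 2 `COc1ccc(/C=C2\S/C(=N\c3ccccc3)N(CC(C)C)C2=O)cc1`: "not determined" (no result reported)
- compound 3 `CC(C)CN1C(=O)/C(=C/c2ccccc2O)S/C1=N\c1ccccc1`: "not determined" (no result reported)

All three entries come from an ADME assay on HepG2 cells (Homo sapiens) for cytotoxicity, read by MTT assay, with a stated time of 48 h (a higher number here means a weaker inhibitor, a lower number a stronger inhibitor), the test followed here. Compound 1 gives > 100000 nM, which is a limit of the test and not a number (the limit of > 100000 nM in this assay, at which 1 of the 3 values shown sits). Compound 3 has no number of its own, its entry being "not determined" (no result reported), so its standing cannot be placed against compound 1. Compound 2 offers no help either, with "not determined" (no result reported) as its entry.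

The next molecule is compound 4 (`CC(C)CN1C(=O)/C(=C/c2ccccn2)S/C1=N\c1ccccc1`). The change is pyridin-2-yl in place of 2-hydroxyphenyl on a double-bonded chain carbon bound to a double-bonded ring carbon, with pyridin-2-yl in place of 2-hydroxyphenyl on a double-bonded chain carbon bound to a double-bonded ring carbon. For the measured compounds named here, no measured pair shows what such a swap does, so no step beyond the usual scatter is expected in this assay, in either direction. Going by the values given here, the only anchor is compound 1 (> 100000 nM), and a result near that limit seems likeliest. For compound 4 the estimated value is 100000 nM, with an expected range from 30000 nM to 200000 nM ( an estimate only ).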

Compound 4, half-maximal inhibitory concentration in the HepG2 assay: > 100000 nM
Compound 4: a limit, no number; the forecaster's own chance of this, stated with the estimate: 60%; the middle value lies on the limit itself.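

In the HepG2 assay compound 1 gives > 100000 nM, which is a limit of the test and not a number. In the HepG2 assay compound 4 gives > 100000 nM, which is also a limit of the test and not a number. The step between these two compounds therefore cannot be read. The compounds shown leave open whether any group at this place gives a readable number in the HepG2 assay. In a physicochemical assay for lipophilicity, measured as octanol-water partition (a higher number here means a more lipophilic compound, a lower number a more polar compound), compound 3 gives 5.08 and compound 4 gives 4.4.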